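This account rests on a few compounds, and the source may have more. Where it says the series, first, only, none or still open, it means among the compounds named here.

Measured so far in a functional assay on HUVEC cells (Homo sapiens); on this read-out higher numbers stand for an effect only at larger amounts of compound and lower numbers for an effect already at smaller amounts:
- compound 1 `COC1=C(C)C(=O)/C(=C(O)/C=C/c2cccc(OC)c2)C(=O)C1(C)C`: < 4 ug/mL
- compound 2 `COC1=C(C)C(=O)/C(=C(O)/C=C/c2ccccc2OC)C(=O)C1(C)C`: < 4 ug/mL

The figure for compound 2, < 4 ug/mL, is a limit of the assay and not a number. The figure for compound 1, < 4 ug/mL, is a limit too. Among the compounds with values here, the series so far therefore rests on (the limit of < 4 ug/mL in this assay, at which 2 of the 2 values shown sit), and the true position of compound 2 remains open.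

The next compound is compound 3 `COC1=C(C)C(=O)/C(=C(O)/C=C/c2ccc(O)cc2)C(=O)C1(C)C`, which carries 4-hydroxyphenyl in place of 2-methoxyphenyl on a double-bonded chain carbon bound to a double-bonded chain carbon.

Within the data shown here, only one measured step bears on this change, a step that the two limits leave unreadable from compound 1 to compound 2. It also concerns the group at this place, but it offers no size to carry over. Among the measured compounds shown here, no measured step involves 4-hydroxyphenyl either. With nothing to set a direction, no step beyond the scatter is expected in this assay, though the uncertainty is wide. The estimated step is a step that the limit leaves unreadable from compound 2 to compound 3. For compound 3 the expected value is 2.5 ug/mL, with an estimated range from 0.6 ug/mL to 8 ug/mL.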

Compound 3, concentration for half-maximal effect: < 4 ug/mL
Compound 3: no number, only a limit; the forecaster's own chance of this, stated with the estimate: 55%; the middle value does not contradict the limit.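

In this assay compound 3 gives < 4 ug/mL, which is a limit of the assay and not a number. The steps linking compound 3 with compound 1 and compound 2 therefore cannot be read. The compounds shown leave open where these three truly stand relative to one another, and the series still rests on a single limit: the limit of < 4 ug/mL in this assay, at which 3 of the 3 values shown sit.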